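From phenyl to 3,4-dichlorophenyl in compound 1

This account rests on a few compounds, and the source may have more. Where it says the series, first, only, none or still open, it means among the compounds named here.

Measured in a functional assay on U-87MG ATCC cells for antiproliferative activity against U-87 MG (Homo sapiens), read by MTT assay, with a stated time of 48 h; a lower number here means a stronger inhibitor, a higher number a weaker inhibitor:
- compound 1 `Cc1nc(-c2ccc(Cl)cc2)sc1C(=O)CSc1nc(-c2ccccc2)c(C#N)c(=O)[nH]1`: 27600 nM
- compound 2 `COc1ccc(-c2nc(C)c(C(=O)CSc3nc(N)c(C#N)c(-c4ccccc4)n3)s2)cc1`: 8540 nM
- compound 3 `COc1ccc(-c2nc(C)c(C(=O)CSc3nc(-c4ccc(Cl)cc4)c(C#N)c(=O)[nH]3)s2)cc1`: 45900 nM

Repeated measurements of this kind never agree exactly, so small gaps between numbers carry no meaning. Compound 1, at 27600 nM, cannot be told apart from compound 3, at 45900 nM, since the two lie within the usual scatter of each other. Compound 2, at 8540 nM, gives a lower number than compound 1, and that gap lies beyond the scatter, so compound 2 is the stronger inhibitor of that pair.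

Compound 4 `Cc1nc(-c2ccc(Cl)cc2)sc1C(=O)CSc1nc(-c2ccc(Cl)c(Cl)c2)c(C#N)c(=O)[nH]1` keeps the core of compound 1 but carries 3,4-dichlorophenyl in place of phenyl on an aromatic carbon. Among the measured compounds shown here, no two measured compounds differ in one place only, so the data offer no direct guide to this change. In this assay, no step beyond the scatter is expected, and no clear direction can be named. The expected change is small: a 1.1-fold lower number from compound 1 to compound 4 (0.04 log units; within the scatter). For compound 4 the estimated value is 25000 nM, with an expected range from 8000 nM to 70000 nM.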

Compound 4, half-maximal inhibitory concentration: 83900 nM
Beside the measured number, compound 4's estimate is 3.4-fold (0.53 log units) below it; measured number outside the range, above it.
By their numbers in this assay, from the lowest: compound 2; then compounds 1, 3 and 4 (each within the scatter of the next, the first and the last beyond it).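

In this assay, putting 3,4-dichlorophenyl in place of phenyl gives a 3.0-fold higher number from compound 1 to compound 4 (0.48 log units; beyond the scatter), a modest step but one beyond the scatter. Among the compounds shown here, this is the only comparison here in which a single place changes, so it shows what the earlier compounds could not: what is attached at this aromatic carbon, next to the ring nitrogen and ortho to a cyano group, can shift the read-out, and here the two added chlorine atoms go with a weaker inhibitor. No measurement of any property of these groups is available to account for the step.

This single pair cannot show whether the two chlorine atoms act together or whether one alone would give the same shift, nor whether the same change would hold on a different core. It also leaves open how this position would respond to a quite different group, such as a small alkyl chain like ethyl, an amine or a carboxylic acid, and whether any replacement for phenyl here would give a lower number rather than a higher one.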